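The source may report more compounds than this note shows. Statements on the series, on what has been measured and on what is new or still open speak of the compounds shown alone.

Compound 1 `O=C(Nc1cccc(F)c1)c1cc(=O)[nH]c2cc(Br)ccc12`: 7500 nM
Compound 2 `O=C(Nc1cccc(F)c1)c1cc(=O)[nH]c2cc(-c3ccsc3)ccc12`: 4500 nM

Both values come from a functional assay on MIA PaCa-2 cells (Homo sapiens) for antiproliferative activity, read by MTT assay, with a stated time of 72 h; a higher number here means a weaker inhibitor, a lower number a stronger inhibitor. Among the measured compounds shown here, the only measured step so far is a 1.7-fold lower number from compound 1 to compound 2 (0.22 log units; within the scatter), so the numbers do not separate compound 2 from compound 1, and compound 2 has no clear standing of its own.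

The next compound is compound 3 `O=C(Nc1cccc(F)c1)c1cc(=O)[nH]c2cc(C3=CCOCC3)ccc12`. The structural change is a group of 6 heavy atoms (5 carbon, 1 oxygen; one six-membered non-aromatic ring with 1 hetero atom) in place of a group of 5 heavy atoms (4 carbon, 1 sulfur; one five-membered aromatic ring with 1 hetero atom), on an aromatic carbon: a group of 6 heavy atoms, with one six-membered non-aromatic ring with 1 hetero atom, takes the place of thiophen-3-yl on an aromatic carbon.

For the measured compounds named here, only one measured step bears on this change: the exchange of bromo for thiophen-3-yl on that same carbon, a 1.7-fold lower number from compound 1 to compound 2 (0.22 log units; within the scatter). Going by the values given here, one step is thin evidence, and no compound with a non-aromatic ring there has been measured. Even so, since that exchange stayed within the scatter, no step beyond the scatter is expected in this assay. The estimated step is a 1.1-fold higher number from compound 2 to compound 3 (0.05 log units; within the scatter). The estimate for compound 3 is 5000 nM, within an expected range from 2000 nM to 12000 nM.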

Compound 3, half-maximal inhibitory concentration: 8800 nM
Beside the measured number, compound 3's estimate is 1.8-fold (0.25 log units) below it, within the range that was stated.
By their numbers in this assay, from the lowest: compounds 2, 1 and 3 (each within the scatter of the next).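

In this assay, among the compounds shown here, the exchange of thiophen-3-yl for a six-membered non-aromatic ring with 1 hetero atom gives a 2.0-fold higher number from compound 2 to compound 3 (0.29 log units; within the scatter) and is the first test of a non-aromatic ring on this aromatic carbon. Putting the same ring in place of bromo gives a 1.2-fold higher number from compound 1 to compound 3 (0.07 log units; within the scatter) and likewise does not separate the two compounds. Among these three compounds, then, a single bromine atom, an aromatic ring and a non-aromatic ring carrying a double bond cannot be told apart by their numbers, and nothing measured here gives a reason for this.

The compounds shown leave open whether any other group on this carbon, such as an amine, a carboxylic acid, a longer alkyl chain or the same six-membered ring without its double bond, would produce a step beyond the scatter. All three compounds also share the rest of the structure, including the amide and its fluorine atom, so they cannot tell how a change elsewhere would affect the number.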